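The source may report more compounds than this note shows. Statements on the series, on what has been measured and on what is new or still open speak of the compounds shown alone.

Measured so far:
compound 1, `CC(C)[C@H](NC(=O)CN(c1nc(Cl)nc2[nH]cnc12)C1CC1)C(=O)OCc1ccccc1`: 27.3%
compound 2, `CC[C@H](C)[C@H](NC(=O)CN(c1nc(Cl)nc2[nH]cnc12)C1CC1)C(=O)O`: 21.4%
compound 3, `CC(C)(C)OC(=O)NCCCC[C@H](NC(=O)CN(c1ncnc2c1ncn2C1CCCCO1)C1CC1)C(=O)OCc1ccccc1`: 28.4%

The numbers come from a functional assay on the whole organism (Tail, strain ICR) with Mus musculus as the target, in the tail flick test, with a stated time of 120 min, at a dose of 25 umol/kg by the oral route; a lower number here means a weaker effect, a higher number a stronger effect of the compound at the dose given. In this assay compound 1 gives 27.3%, compound 3 gives 28.4%, and compound 2 gives 21.4%. The number for compound 1 is within the usual scatter of the number for compound 3 and also of the number for compound 2, so the three compounds cannot be told apart on what has been measured; they share a core, and all give a modest effect at this dose.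

The next compound, compound 4, `NC(=O)C[C@H](NC(=O)CN(c1nc(Cl)nc2[nH]cnc12)C1CC1)C(=O)OCc1ccccc1`, has not yet been measured in this assay. Set against compound 1 it differs in one place: carbamoylmethyl in place of isopropyl on a saturated chain carbon bound to an amide-type nitrogen and a carbonyl carbon.

For the measured compounds named here, no pair of measured compounds differs in exactly one place, so there is no measured step to set a scale for this change. Since the three measured numbers all lie within the scatter of one another, the expectation for compound 4 is that the step from compound 1 is small, with no clear direction, and the estimated step of a number 2.3 percentage points lower from compound 1 to compound 4 (within the scatter) stays within the scatter. On this basis compound 4 is estimated to give about 25%, with a likely range from 10% to 40%.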

Compound 4, a percentage reported as activity, at one dose (the size of the read-out at that dose, not a potency): 15.1%
Compound 4: middle estimate off by 9.9 percentage points, on the high side, and the stated range covers the measured number.
By their numbers in this assay, from the lowest: compounds 4, 2, 1 and 3 (each within the scatter of the next, the first and the last beyond it).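

For the compounds shown here, the swap of isopropyl for carbamoylmethyl, on a saturated chain carbon bound to an amide-type nitrogen and a carbonyl carbon, gives the first step in this assay that can be read, namely a number 12.2 percentage points lower from compound 1 to compound 4 (beyond the scatter), and so the first measured change between two compounds that differ in one place. It shows that this position is not indifferent to the group it carries, which the three earlier compounds, all within the scatter of their nearest neighbours and none differing from another in one place, could not show. The group that enters brings a hydrogen-bond donor and a hydrogen-bond acceptor where the isopropyl group had neither, but nothing measured here ties the lower number to either of them or to any other feature of the swap.

A single step cannot tell whether the lower number goes with the amide in the new group or with the group as a whole, and an aminomethyl group or a longer plain carbon chain on the same carbon would help to separate the two. As far as these compounds go, it also remains open whether the same swap would give a similar step with a carboxylic acid in place of the benzyl ester.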